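Three Compounds at the Assay Limit, a Fourth Awaits

The compounds below may be only part of what the source reports. "The series", "measured", "known", "first", "only" and "open" are said of these compounds alone.

Compound 1 `COc1ccc(Oc2ccccc2-c2ccsc2S(=O)(=O)N2CCN(C(=O)Nc3ccc([N+](=O)[O-])cc3)CC2)cc1OC`: > 50000 nM
Compound 2 `COc1cccc(NC(=S)NCCNS(=O)(=O)c2ccc(-c3ccccc3Oc3ccc([N+](=O)[O-])cc3)s2)c1`: > 50000 nM
Compound 3 `Cc1cc(C)cc(NC(=O)NCCNS(=O)(=O)c2ccc(-c3ccccc3OCc3ccccc3)s2)c1`: > 50000 nM

In a functional assay on RS4-11 cells (Homo sapiens) for inhibition, read by CCK-8 assay, with a stated time of 48 h (on this read-out higher numbers stand for weaker inhibition and lower numbers for stronger inhibition), compound 1 gives > 50000 nM, which is a limit of the assay rather than a measured number. Compound 2 likewise gives > 50000 nM in this assay, again a limit. Compound 3 gives > 50000 nM in this assay, also a limit. All three values therefore sit at the limit of > 50000 nM in this assay, at which 3 of the 3 values shown sit, and compound 3 stands exactly where the other two stand: no number separates it from them, and no ordering among the three can be read from these results. For the measured compounds named here, no two of the measured compounds differ from one another in a single place, so no measured step in this assay is available.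

Compound 4 `O=[N+]([O-])c1ccc(NC(=S)NCCNS(=O)(=O)c2ccc(-c3ccccc3OCc3ccccc3)s2)cc1` is the next compound. It differs from compound 3 by a group of 12 heavy atoms (7 carbon, 2 nitrogen, 2 oxygen, 1 sulfur; one six-membered aromatic ring of carbon only) in place of a group of 11 heavy atoms (9 carbon, 1 nitrogen, 1 oxygen; one six-membered aromatic ring of carbon only), on an amine nitrogen.

Because compound 3 gives only the limit > 50000 nM, the step that the limit leaves unreadable from compound 3 to compound 4 is expected to be essentially none beyond the usual scatter. Compound 4 is expected to give about 60000 nM, most plausibly between 20000 nM and 200000 nM, with a high chance that this assay again returns only a limit.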

Compound 4, half-maximal inhibitory concentration: 11300 nM
Compound 4: the middle estimate sits 5.3-fold (0.73 log units) above what was measured, outside the stated range (below it).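

In this assay compound 3 gives > 50000 nM, which is a limit of the assay and not a number. Replacing the (3,5-dimethylphenyl)carbamoyl group on the amine nitrogen with the new group, which carries sulfur and a nitro group, gives an at least 4.4-fold lower number from compound 3 to compound 4 (0.64 log units; beyond the scatter), a change beyond the usual scatter, and the true step could be larger since it starts from a limit. This shows for the first time that a change at this position can shift the read-out, and compound 4, at 11300 nM, is the only compound of the four with an actual number, while the others give no ordering: the limit of > 50000 nM in this assay, at which 3 of the 4 values shown sit.

The entering group differs from the leaving one in more than one way, since sulfur takes the place of the carbonyl oxygen and the ring carries a nitro group in place of two methyl groups, so the compounds shown cannot say which of these changes accounts for the step. On these data alone, it also remains open how the read-out would respond if an amine or a carboxylic acid stood on that ring in place of the nitro group.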